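Aryl amide variation on the shared core: compound 4

The source may hold more compounds than are shown below. What is called first, only, known or untested is meant among the compounds shown, and "the series" means these compounds.

For the measured compounds named here, compound 3 `COc1cccc(C(=O)Nc2cccc(-c3oc4cc(-c5ccc(F)cc5)ccc4c(=O)c3O)c2)c1` gives 9950 nM in a functional assay on HepG2 cells (Homo sapiens) for antiproliferative activity, read by CCK-8 assay, with a stated time of 72 h (on this read-out lower numbers stand for stronger inhibition and higher numbers for weaker inhibition), the second highest of the three numbers measured so far; compound 1 `O=C(Nc1cccc(-c2oc3cc(-c4ccc(F)cc4)ccc3c(=O)c2O)c1)c1ccc(F)cc1` at 9280 nM lies within the scatter of it, while compound 2 `O=C(Nc1cccc(-c2oc3cc(-c4ccc(F)cc4)ccc3c(=O)c2O)c1)c1ccc(C(F)(F)F)cc1` at 42700 nM is the furthest off. Compound 4 `COc1ccc(C(=O)Nc2cccc(-c3oc4cc(-c5ccc(F)cc5)ccc4c(=O)c3O)c2)c(F)c1` carries 2-fluoro-4-methoxyphenyl in place of 3-methoxyphenyl on a carbonyl carbon. Going by the values given here, no measured step covers a fluoro added to the amide aryl group alongside a methoxy. The nearest comparisons are a 1.1-fold higher number from compound 1 to compound 3 (0.03 log units; within the scatter) and a 4.6-fold higher number from compound 1 to compound 2 (0.66 log units; beyond the scatter): exchanging one aryl amide substituent for another left the number unchanged, whereas the bulkier trifluoromethyl gave a modest loss. For a change of this size no step beyond the scatter is expected in this assay: a 1.0-fold higher number from compound 3 to compound 4 (0.00 log units; within the scatter). Compound 4 is therefore estimated at 10000 nM, within 4000 nM to 25000 nM.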

Compound 4, half-maximal inhibitory concentration: 45300 nM
Beside the measured number, compound 4's estimate is 4.5-fold (0.66 log units) below it, outside the stated range (above it).
By their numbers in this assay, from the lowest: compounds 1 and 3 (each within the scatter of the next); then compounds 2 and 4 (each within the scatter of the next).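

The methoxy-bearing aryl amide does not keep the number of compound 3 once the group becomes 2-fluoro-4-methoxyphenyl (a 4.6-fold higher number from compound 3 to compound 4 (0.66 log units; beyond the scatter)), and the same loss shows against the 4-fluorophenyl amide (a 4.9-fold higher number from compound 1 to compound 4 (0.69 log units; beyond the scatter)). This change reaches the level of the 4-(trifluoromethyl)phenyl amide (a 1.1-fold higher number from compound 2 to compound 4 (0.03 log units; within the scatter)), so a loss on this aryl group is not tied to trifluoromethyl alone. Nothing available explains the loss.

The compounds shown do not separate the added fluoro from the moved methoxy, as a 4-methoxyphenyl amide lies outside them. As far as these compounds go, how an amine or a carboxylic acid on the amide aryl group would read in this assay stays open.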